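The source may report more compounds than this note shows. Statements on the series, on what has been measured and on what is new or still open speak of the compounds shown alone.

Measured compounds:
- compound 1 `CN1CCC[C@H]1COc1cccnc1Br` — > 1000000 nM
- compound 2 `CN1CCC[C@H]1COc1cnccc1Br` — > 1000000 nM
- compound 3 `Cc1cncc(OC[C@@H]2CCCN2C)c1` — 2300 nM

The three share a core in which a methylpyrrolidinylmethoxy group hangs from a pyridine ring, and they were tested in an assay on K177 cells for activation of Neuronal acetylcholine receptor; alpha4/beta2 (Homo sapiens); a lower number here means that less compound is needed, a higher number that more compound is needed for the effect. For compound 1 the value > 1000000 nM is a limit of the assay, not a number. For compound 2 the value > 1000000 nM is likewise a limit. Compound 3 is thus the only one of the three with a measured number, giving 2300 nM in this assay, while the other two sit at the limit of > 1000000 nM in this assay, at which 2 of the 3 values shown sit.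

Compound 4 `CCCc1cncc(OC[C@@H]2CCCN2C)c1` has not yet been measured in this assay. It differs from compound 3 by ethyl in place of hydrogen on a saturated chain carbon bound to an aromatic carbon. Among the compounds with values here, no measured pair here shows what such a lengthening does, so the direction can only be a guess. A step of some size toward weaker activation is expected, beyond the usual scatter, a 4.3-fold higher number from compound 3 to compound 4 (0.64 log units; beyond the scatter). Compound 4 is therefore estimated at 10000 nM in this assay, with a range from 2500 nM to 60000 nM.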

Compound 4, half-maximal effective concentration: > 1000000 nM
Compound 4 ended at the assay's limit (the forecaster's own chance of this, stated with the estimate: 10%); middle value at least 100-fold (2.00 log units) away from the limit.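

In this assay compound 4 gives > 1000000 nM, which is a limit of the assay and not a number. Ethyl in place of hydrogen on a saturated chain carbon bound to an aromatic carbon gives an at least 430-fold higher number from compound 3 to compound 4 (2.63 log units; beyond the scatter), the first step in this set that can be read, and it shows that this place does not tolerate the change from methyl to propyl in this assay. Compound 3 therefore remains the only compound shown with a measured number, and the lengthening takes the series to the limit already seen for compound 1 and compound 2: the limit of > 1000000 nM in this assay, at which 3 of the 4 values shown sit.

The limit leaves open how much higher the true number of compound 4 lies. From the compounds shown here alone, it also remains open whether an ethyl, isopropyl or methoxy group at this place would still give a measurable number.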